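This account rests on a few compounds, and the source may have more. Where it says the series, first, only, none or still open, it means among the compounds named here.

Values in a physicochemical assay for lipophilicity, at pH 7.4; on this read-out higher numbers stand for higher lipophilicity and lower numbers for lower lipophilicity:

- Compound 1 `CNC(=O)c1cc(C(=O)NC2CC2)cc2c1OC[C@H]2c1cccc2[nH]ccc12`: 3.5
- Compound 2 `CNC(=O)c1cc(C(=O)N[C@H]2[C@@H]3COC[C@@H]32)cc2c1OC[C@H]2c1cccc2[nH]ccc12`: 3.1
- Compound 3 `CNC(=O)c1cc(C(=O)N[C@H]2[C@@H]3C[C@@H](O)C[C@@H]32)cc2c1OC[C@H]2c1ccccc1`: 2.9

Compound 2 lies within the scatter of compound 3, while compound 1 stands higher than compound 2 by more than the scatter. The account now turns to compound 4 `CNC(=O)c1cc(C(=O)N[C@H]2[C@@H]3COC[C@@H]32)cc2c1OC[C@H]2C1CCOCC1`, which has not yet been measured. It carries oxan-4-yl in place of 1H-indol-4-yl on a saturated ring carbon, two ring bonds from the ring oxygen: oxan-4-yl in place of 1H-indol-4-yl on a saturated ring carbon.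

For the measured compounds named here, no measured step changes the group at this place. Compound 3 differs from compound 2 in more than one place, so it offers no clean comparison. The nearest guide is a number 0.40 log units lower from compound 1 to compound 2 (beyond the scatter), a modest fall on an amide-type nitrogen, where the entering group also contains a ring oxygen. A fall in this assay is therefore expected here too, and a larger one, since the aromatic rings of 1H-indol-4-yl leave as well. The expected change is a number 1.30 log units lower from compound 2 to compound 4 (beyond the scatter). For compound 4 the estimated value is 1.8, with an expected range from 1.3 to 2.3.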

Compound 4, distribution coefficient: 2.1
The estimate for compound 4 lay 0.30 log units below the measured number; measured number inside the range.
By their numbers in this assay, from the lowest: compound 4; then compounds 3 and 2 (each within the scatter of the next); then compound 1.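

For the compounds shown here, this is the first measured change at this place, on a saturated ring carbon of the five-membered ring with 1 oxygen, and it shows that this assay responds strongly to the group held there. Replacing 1H-indol-4-yl with oxan-4-yl gives a number 1.00 log units lower from compound 2 to compound 4 (beyond the scatter), a larger step than a number 0.40 log units lower from compound 1 to compound 2 (beyond the scatter), which was seen on the amide-type nitrogen. The change removes both aromatic rings and the hydrogen-bond donor while adding a ring oxygen, and no data shown here give a reason for the size of the step.

Going by these compounds alone, the single step cannot show how much of the fall belongs to the loss of the aromatic rings and how much to the ring oxygen. A cyclohexyl group at this place, compared directly with oxan-4-yl, would separate the contribution of that oxygen from the ring it sits in.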